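The source may report more compounds than this note shows. Statements on the series, on what has been measured and on what is new or still open speak of the compounds shown alone.

Working notes on the series. Compound 1 `COc1ccc(NC(=O)CCCCCCNC(=O)C(O)(O)C(F)(F)F)cc1` gives 51000 nM in an assay on isolated protein for inhibition of histone deacetylase 8 (Homo sapiens), read by chemiluminescence, with a stated time of 3 h; a lower number here means a stronger inhibitor, a higher number a weaker inhibitor. Within the data shown here, compound 2 `O=C(CCCCCCNC(=O)C(O)(O)C(F)(F)F)Nc1ccc(Br)cc1` gives 11000 nM in this assay, the lowest of the two numbers so far; the only measured step is a 4.6-fold lower number from compound 1 to compound 2 (0.67 log units; beyond the scatter). Compound 3 `O=C(CCCCCCNC(=O)C(O)(O)C(F)(F)F)Nc1ccc(-c2ccccc2)cc1` differs from compound 2 by phenyl in place of bromo on an aromatic carbon. The bromo-for-methoxy step is the only one that bears on this, and it was modest; a further modest step downward is therefore expected, without a measured precedent for phenyl. Compound 3 is expected to give 4500 nM in this assay, within 1500 nM to 15000 nM. The expected step is a 2.4-fold lower number from compound 2 to compound 3 (0.39 log units; beyond the scatter).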

Compound 3, half-maximal inhibitory concentration: 4100 nM
Compound 3: the middle estimate sits 1.1-fold (0.04 log units) above what was measured; the range from low to high includes it.
By their numbers in this assay, from the lowest: compound 3; then compound 2; then compound 1.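

In this assay, this aromatic carbon accepts a phenyl of 6 heavy atoms in place of a single bromo, with a 2.7-fold lower number from compound 2 to compound 3 (0.43 log units; beyond the scatter), so a whole second aromatic ring costs nothing here. Set against the methoxy, phenyl gives a 12-fold lower number from compound 1 to compound 3 (1.09 log units; beyond the scatter), the first large step in the series. No measurement at hand accounts for either step. From the compounds shown here alone, whether an amine or a carboxylic acid at this carbon would keep the number falling remains open. So does whether phenyl bearing its own further group would go lower than compound 3.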